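Cyclohexyloxy for (2-isopropylphenyl)amino: compound 2 to compound 4

The source may report more compounds than this note shows. Statements on the series, on what has been measured and on what is new or still open speak of the compounds shown alone.

In a functional assay on Shh Light II cells (Mus musculus) for inhibition, read by a luciferase reporter (a higher number here means a weaker inhibitor, a lower number a stronger inhibitor), compound 2 `CC(C)c1ccccc1NC(=O)N1CCC(c2nc(-c3ccc4ccccc4n3)no2)CC1` gives 480 nM as the highest of the three numbers in hand. Compound 1 `O=C(Nc1ccccc1Cl)N1CCN(c2nc(-c3ccc4ccccc4n3)no2)CC1` gives 140 nM and compound 3 `Cn1c(-c2noc(C3CCN(C(=O)NC4CCCCC4)CC3)n2)nc2ccccc21` gives 89 nM in the same test, both lower than compound 2 by more than the scatter. Compound 4 `O=C(OC1CCCCC1)N1CCC(c2nc(-c3ccc4ccccc4n3)no2)CC1` has not yet been measured. It carries cyclohexyloxy in place of (2-isopropylphenyl)amino on a carbonyl carbon, with cyclohexyloxy in place of (2-isopropylphenyl)amino on a carbonyl carbon as the counted change. Among the compounds with values here, no measured pair isolates this change, so the step has no direct precedent. Within the data shown here, compound 3 also holds a six-membered non-aromatic ring of carbon only and gives 89 nM as the lowest number so far, although it also differs from compound 2 elsewhere. A modest move towards a stronger inhibitor in this assay is therefore expected, only a little beyond the scatter. The estimated step is a 2.4-fold lower number from compound 2 to compound 4 (0.38 log units; beyond the scatter) on this reasoning. For compound 4 the estimated value is 200 nM with an expected range from 60 nM to 700 nM in this test.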

Compound 4, half-maximal inhibitory concentration: 580 nM
Beside the measured number, compound 4's estimate is 2.9-fold (0.46 log units) below it; the range from low to high includes it.
By their numbers in this assay, from the lowest: compounds 3 and 1 (each within the scatter of the next); then compounds 2 and 4 (each within the scatter of the next).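

In this assay, replacing (2-isopropylphenyl)amino with cyclohexyloxy on the carbonyl carbon gives a 1.2-fold higher number from compound 2 to compound 4 (0.08 log units; within the scatter), so the two groups cannot be told apart at this position. The exchange swaps an aromatic carbon ring for a non-aromatic one, removes the hydrogen-bond donor, adds a hydrogen-bond acceptor and leaves fewer heavy atoms, yet it produces no readable change on this core. Nothing available explains why the two groups read alike.

The pair changes the ring and the linking atom together, so the separate contribution of each stays unresolved. Phenoxy and cyclohexylamino on this same carbonyl carbon and core would separate the two, and a longer chain such as hexyloxy would test whether a ring is needed here at all.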